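The source may report more compounds than this note shows. Statements on the series, on what has been measured and on what is new or still open speak of the compounds shown alone.

Series notes. For the measured compounds named here, compound 1 `CCCCCCCCN1C(=O)[C@H](Cc2ccc(-c3cccc(CN(CCCC)C(C)=O)c3)cc2)N(C)C(=O)[C@@H]1C` is the only compound with a single number in a functional assay on cells for agonist activity at follicle-stimulating hormone receptor (Homo sapiens), read by cAMP accumulation; a lower number here means that less compound is needed, a higher number that more compound is needed for the effect; in that assay compound 1 gives 35 nM, and a further entry for it carries no single number. Compound 2 `CCCCCCN1C(=O)[C@H](Cc2ccc(-c3cccc(CN(CCCC)C(=O)OC)c3)cc2)N(C)C(=O)[C@@H]1C` gives 48 nM; 59 nM (2 entries) in this assay; its repeats, (the several entries of compound 2 in this assay, 48 nM; 59 nM (2 entries)), sit close to each other. Compound 3 `CCCCCCCCN1C(=O)[C@H](Cc2ccc(-c3cccc(CN(CCCC)C(=O)OC)c3)cc2)N(C)C(=O)[C@@H]1C` is not yet measured. From compound 1 it differs by methoxy in place of methyl on a carbonyl carbon. Going by the values given here, no step between measured compounds is available for this change, so the expected step of a 1.1-fold higher number from compound 1 to compound 3 (0.06 log units; within the scatter) is kept within the usual scatter. Compound 3 is estimated at 40 nM, with a range of 18 nM to 90 nM.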

Compound 3, half-maximal effective concentration: 31 nM
Compound 3: the middle estimate sits 1.3-fold (0.11 log units) above what was measured; the measured number falls inside the stated range.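

In this assay, for the compounds shown here, the first direct comparison at this carbonyl carbon, whose other neighbour is the amide-type nitrogen, gives a 1.1-fold lower number from compound 1 to compound 3 (0.05 log units; within the scatter). Acetyl and methoxycarbonyl therefore cannot be told apart here, even though methoxy brings an extra oxygen and a hydrogen-bond acceptor. For scale, repeat entries of a single compound read: the several entries of compound 2 in this assay, 48 nM; 59 nM (2 entries)

Still open, going by these compounds, is how a larger group on this carbonyl carbon, such as butoxy or dimethylamino, would read. This single pair also leaves open whether the step would hold with a different chain on the shared core.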